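Methyl in place of hydrogen on the linking nitrogen

The source may report more compounds than this note shows. Statements on the series, on what has been measured and on what is new or still open speak of the compounds shown alone.

Values in an assay for inhibition of Amine oxidase [flavin-containing] B (Bos taurus), read by fluorescence; on this read-out lower numbers stand for stronger inhibition and higher numbers for weaker inhibition:
compound 1 `Cn1c(C(=O)Nc2ccccc2)cc2ccccc21` gives > 100000 nM, a limit of the assay and not a number.
compound 2 `CN(C(=O)c1cc2ccccc2n1C)c1ccccc1` gives 21 nM.
compound 3 `Cn1c(CNc2ccccc2)cc2ccccc21` gives 75000 nM.

Compound 2 differs from compound 1 by methyl in place of hydrogen on an amide-type nitrogen. The step is an at least 4700-fold lower number from compound 1 to compound 2 (3.67 log units; beyond the scatter), with compound 1 sitting at the limit of > 100000 nM in this assay, at which 1 of the 3 values shown sits. Compound 3 has the higher of the two numbers, compound 2 the lower. The difference between the cores of compound 1 and compound 3 is not broken down here.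

Compound 4 `CN(Cc1cc2ccccc2n1C)c1ccccc1` differs from compound 3 by methyl in place of hydrogen on a nitrogen on an aromatic ring. This is the same kind of change as from compound 1 to compound 2, not the same: here the nitrogen is one on an aromatic ring whose other neighbours are aromatic carbon and saturated chain carbon, whereas in compound 1 it is an amide-type nitrogen whose other neighbours are aromatic carbon and carbonyl carbon. The expected step is a 38-fold lower number from compound 3 to compound 4 (1.57 log units; beyond the scatter), resting on the measured at least 4700-fold lower number from compound 1 to compound 2 (3.67 log units; beyond the scatter) but taken as smaller, since the surroundings of the nitrogen differ. For compound 4 the expected value is 2000 nM, estimated to lie between 200 nM and 20000 nM.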

Compound 4, inhibition constant: 11000 nM
Beside the measured number, compound 4's estimate is 5.5-fold (0.74 log units) below it, and the stated range covers the measured number.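

In this assay, methyl in place of hydrogen on the linking nitrogen gives a lower number on the core of compound 3 as well, with a 6.8-fold lower number from compound 3 to compound 4 (0.83 log units; beyond the scatter), so the direction of the step holds on both cores shown. Its size does not carry over, and two pairs give no reason for the gap: the same change on two cores in this assay, an at least 4700-fold lower number (3.67 log units; beyond the scatter) from compound 1 to compound 2 and a 6.8-fold lower number (0.83 log units; beyond the scatter) from compound 3 to compound 4, at least 690-fold (2.84 log units) apart, beyond the scatter of two such steps. Compound 1 gives a limit of the assay and not a number, so the first step has no exact size: the limit of > 100000 nM in this assay, at which 1 of the 4 values shown sits.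

Still open, as far as these compounds go, is whether ethyl in place of methyl on the linking nitrogen would keep the numbers of compound 2 and compound 4. Also open, from the compounds shown here alone, is whether a third kind of link, such as a sulfonamide, would give a step closer to the large one or the modest one.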